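Trifluoromethyl in Place of Hydrogen: Compound 3 to Compound 4

The source may hold more compounds than are shown below. What is called first, only, known or untested is meant among the compounds shown, and "the series" means these compounds.

Of the compounds shown here, three have so far been measured in a functional assay on HeLa cells (Homo sapiens) for antiproliferative activity, read by MTT assay, with a stated time of 12 h; a higher number here means a weaker inhibitor, a lower number a stronger inhibitor. Compound 1 `COc1ccc2oc(/C=C/c3ccc(OC(F)(F)F)cc3)cc(=O)c2c1` gives 9000 nM. Compound 2 `COc1cc(OC)c2c(=O)cc(/C=C/c3ccncc3)oc2c1` gives 18800 nM, and compound 3 `COc1cc(OC)c2c(=O)cc(/C=C/c3ccccc3)oc2c1` gives 10100 nM. Among these three numbers compound 3 holds the second highest place; its value and that of compound 1 sit close together, and the one single-point step known, a 1.9-fold lower number from compound 2 to compound 3 (0.27 log units; within the scatter), also stays within the scatter.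

Compound 4 `COc1cc(OC)c2c(=O)cc(/C=C/c3ccc(C(F)(F)F)cc3)oc2c1` differs from compound 3 in one place: trifluoromethyl in place of hydrogen on an aromatic carbon. Within the data shown here, no measured step adds a group to this aromatic ring, so none bears on the change directly. The nearest guide is compound 1, which carries a trifluoromethoxy group on a differently substituted core and whose value of 9000 nM lies within the scatter of compound 3. Among the measured compounds shown here, the only single-point step, a 1.9-fold lower number from compound 2 to compound 3 (0.27 log units; within the scatter), swapped the whole ring without moving the number beyond the scatter. The expected outcome is therefore a 1.0-fold lower number from compound 3 to compound 4 (0.00 log units; within the scatter), meaning no change beyond the scatter. Compound 4 is estimated at 10000 nM, with a range from 4000 nM to 25000 nM.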

Compound 4, half-maximal inhibitory concentration: 19000 nM
Compound 4: the middle estimate sits 1.9-fold (0.28 log units) below what was measured, and the stated range covers the measured number.
By their numbers in this assay, from the lowest: compounds 1, 3, 2 and 4 (each within the scatter of the next, the first and the last beyond it).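

In this assay the change gives a 1.9-fold higher number from compound 3 to compound 4 (0.27 log units; within the scatter), so a trifluoromethyl group of 4 heavy atoms can stand on this aromatic carbon, para to a large group, without moving the number beyond the scatter. Among these compounds, this is the first measured case of a group taking the place of hydrogen on this ring while the shared core stays the same, whereas the earlier step exchanged the whole ring. A single group tells nothing yet about a trend at this position.

As far as these compounds go, whether an amine or a carboxylic acid on this same aromatic carbon would move the number beyond the scatter of compound 3 remains open. No measurement at hand explains the result for compound 4.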